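The source may report more compounds than this note shows. Statements on the series, on what has been measured and on what is new or still open speak of the compounds shown alone.

Of the compounds shown here, two have a number so far in a functional assay on cells for antagonist activity at C-C chemokine receptor type 4 (Homo sapiens), read by fluorescence and calcium flux, with stated times of 2.5 s and 45 s; a lower number here means a stronger inhibitor, a higher number a weaker inhibitor. Compound 1, with the structure `Cc1nn([C@H](C)c2ccc(Cl)cc2Cl)c2nc(N3CC[C@H](N4CCC[C@H]4CCS(C)(=O)=O)[C@H](C)C3)cnc12`, gives 104 nM in this assay. Compound 2, with the structure `C[C@@H]1CC(c2cnc3c(C#N)nn([C@H](C)c4ccc(Cl)cc4Cl)c3n2)=CC[C@@H]1N1CCC[C@H]1C`, gives 34 nM in this assay. Of these two numbers, compound 1 carries the higher one, and the gap to compound 2 lies beyond the usual scatter.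

Compound 3, with the structure `Cc1nn([C@H](C)c2ccc(Cl)cc2Cl)c2nc(N3CC[C@H](N4CCC[C@H]4CCC#N)[C@H](C)C3)cnc12`, has not yet been measured in this assay. It differs from compound 1 in one place: cyano in place of methylsulfonyl on a saturated chain carbon, two bonds along the chain from a saturated ring carbon. Among the measured compounds shown here, no measured pair in this set shows this kind of exchange, so there is no step to lean on. The step from compound 1 to compound 3 is expected to be small, a 1.4-fold higher number from compound 1 to compound 3 (0.16 log units; within the scatter), hardly beyond the scatter. For compound 3 the estimate in this assay is 150 nM, with a range from 50 nM to 450 nM.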

Compound 3, half-maximal inhibitory concentration: 41 nM
Compound 3: the middle estimate sits 3.7-fold (0.56 log units) above what was measured; measured number below the stated range.
By their numbers in this assay, from the lowest: compounds 2 and 3 (each within the scatter of the next); then compound 1.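

Exchanging methylsulfonyl for cyano on a saturated chain carbon, two bonds along the chain from a saturated ring carbon, gives a 2.5-fold lower number from compound 1 to compound 3 (0.40 log units; beyond the scatter) in this assay, so the number at this position depends on the group at the end of the chain. The methylsulfonyl group, with its 4 heavy atoms, is not needed here to keep inhibition, since compound 3 carries cyano, with 2 heavy atoms, and has the lower number. No measurement at hand bears on why the number drops.

On these data alone, whether an amine, a carboxylic acid or a primary amide at the same place would lower the number further or raise it remains open, as does the effect of a longer chain ending in cyano. Compound 2 differs from compound 1 and compound 3 in more than one place, so it does not help to answer this.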